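Urea series: cytotoxicity limits and a trifluoromethoxy analogue

The source may hold more compounds than are shown below. What is called first, only, known or untested is meant among the compounds shown, and "the series" means these compounds.

Compound 3 `Cc1cc(NC(=O)Nc2ccc(Cl)cc2)c2ccccc2n1` is the chloro member of the set. In an ADME assay on Raji cells (Homo sapiens) for cytotoxicity, with a stated time of 72 h (on this read-out higher numbers stand for an effect only at larger amounts of compound and lower numbers for an effect already at smaller amounts), compound 3 gives > 25000 nM, which is a limit of the assay and not a number. Compound 1 `Cc1ccc(NC(=O)Nc2cc(C)nc3ccccc23)cc1` gives > 25000 nM in this assay, again a limit rather than a number. Compound 2 `CC(=O)c1ccc(NC(=O)Nc2cc(C)nc3ccccc23)cc1` gives > 25000 nM, also a limit. All three values fall on (the limit of > 25000 nM in this assay, at which 3 of the 3 values shown sit), so the steps a step that the two limits leave unreadable from compound 1 to compound 2, a step that the two limits leave unreadable from compound 1 to compound 3 and a step that the two limits leave unreadable from compound 2 to compound 3 cannot be read in size or direction. Compound 4 `Cc1cc(NC(=O)Nc2ccc(OC(F)(F)F)cc2)c2ccccc2n1` differs from compound 3 by trifluoromethoxy in place of chloro on an aromatic carbon. Within the data shown here, no measured step bears on this change, and the three values shown give no spread from which a direction could be taken. The expectation is therefore that compound 4 remains at the same limit, and the estimated step is a step that the limit leaves unreadable from compound 3 to compound 4, nothing beyond the scatter. The estimate for compound 4 in this assay is 30000 nM, with an expected range from 15000 nM to 60000 nM.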

Compound 4, half-maximal effective concentration: 10000 nM
The estimate for compound 4 lay 3.0-fold (0.48 log units) above the measured number; measured number below the stated range.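

In this assay, among these compounds, this place, para to a large group, gives a readable change for the first time: an at least 2.5-fold lower number from compound 3 to compound 4 (0.39 log units; beyond the scatter) comes with trifluoromethoxy in place of chloro. The direction is the same against the other two members, with an at least 2.5-fold lower number from compound 2 to compound 4 (0.39 log units; beyond the scatter) for the change from acetyl and an at least 2.5-fold lower number from compound 1 to compound 4 (0.39 log units; beyond the scatter) for the change from methyl, so among the groups shown only trifluoromethoxy moves the read-out off the limit. Each of these steps gives only a bound on its size, as its starting value is a limit of the assay: the limit of > 25000 nM in this assay, at which 3 of the 4 values shown sit.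

From the compounds shown here alone, whether a methoxy, a trifluoromethyl or an amine at this place would also give a lower number remains open. The steps among compound 1, compound 2 and compound 3 cannot be read, and a single number cannot show how far the read-out might fall.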